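The source may report more compounds than this note shows. Statements on the series, on what has been measured and on what is new or still open speak of the compounds shown alone.

Compound 1 `CC(C)CCn1ccc(-c2ccccc2)c(C#N)c1=O` is the starting point. In a functional assay on CHO cells for positive allosteric modulation of metabotropic glutamate receptor 2 (Homo sapiens), read by scintillation counting and GTPgammaS binding, with a stated time of 30 min (on this read-out lower numbers stand for smaller maximal responses and higher numbers for larger maximal responses), compound 1 gives 117%, the lowest of the three measured numbers. Going by the values given here, compound 2 `COc1ccccc1-c1ccn(CCC(C)C)c(=O)c1C#N` gives 120%; the single change of a number 3 percentage points higher from compound 1 to compound 2 (within the scatter) lies within the scatter. Compound 3 `COc1ccc(-c2ccn(CCC(C)C)c(=O)c2C#N)cc1F` differs from compound 1 in two places. Compound 3 gives 160%, a number beyond the scatter from that of compound 1. Compound 4 `Cc1ccc(Oc2ccc(-c3ccn(CCC(C)C)c(=O)c3C#N)cc2)c(C)n1` differs from compound 1 by (2,6-dimethylpyridin-3-yl)oxy in place of hydrogen on an aromatic carbon. Among the compounds with values here, only the step from compound 1 to compound 2 bears on this change, and it was small; no measured compound carries a group of this size, so the expectation is uncertain. Compound 4 is expected to give 135%, with a range from 100% to 170%. The expected step, a number 18 percentage points higher from compound 1 to compound 4 (beyond the scatter), is estimated as modest and upward.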

Compound 4, largest response reached (Emax), in percent of the reference or control that the assay uses: 246%
Estimate against measurement, compound 4: 111 percentage points below, outside the stated range (above it).
By their numbers in this assay, from the lowest: compounds 1 and 2 (each within the scatter of the next); then compound 3; then compound 4.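

On an aromatic carbon para to a large group, a much larger substituent than any seen earlier is accepted in this assay: (2,6-dimethylpyridin-3-yl)oxy in place of hydrogen brings a number 129 percentage points higher from compound 1 to compound 4 (beyond the scatter). The smaller methoxy change, with a number 3 percentage points higher from compound 1 to compound 2 (within the scatter), gave no sign that one added group could raise the maximal response this far. Nothing available explains the rise. Going by these compounds, it remains open whether the gain depends on the two methyl groups, the ring nitrogen or the oxygen link. A plain phenoxy group, or an amine link in place of the oxygen, could help separate these parts.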